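The compounds below may be only part of what the source reports. "The series", "measured", "known", "first", "only" and "open" are said of these compounds alone.

Measured compounds:

Compound 1 `CCOC(=O)C1=C(N/C=N/c2cccnc2Cl)Nc2[nH]nc(C)c2C1c1ccc(N(C)C)cc1`: 4890 nM
Compound 2 `CCOC(=O)C1=C(NN=C(C(C)=O)C(C)=O)Nc2[nH]nc(C)c2C1c1ccc(N(C)C)cc1`: 8480 nM
Compound 3 `CCOC(=O)C1=C(N)Nc2[nH]nc(C)c2C1c1ccc(N(C)C)cc1`: 4240 nM

In a functional assay on HepG2 cells (Homo sapiens) for inhibition, read by MTT assay, with a stated time of 48 h (on this read-out higher numbers stand for weaker inhibition and lower numbers for stronger inhibition), compound 2 gives the highest of the three numbers, yet its two neighbours lie close: the step of a 1.7-fold higher number from compound 1 to compound 2 (0.24 log units; within the scatter) and the step of a 2.0-fold lower number from compound 2 to compound 3 (0.30 log units; within the scatter) are both within the scatter, as is the step of a 1.2-fold lower number from compound 1 to compound 3 (0.06 log units; within the scatter). On these numbers, then, compound 2 cannot be set apart from compound 1 or compound 3.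

Compound 4 `CCOC(=O)C1=C(N/N=C(/C(C)=O)C(=O)OCC)Nc2[nH]nc(C)c2C1c1ccc(N(C)C)cc1` has not yet been measured. It differs from compound 2 by a group of 10 heavy atoms (6 carbon, 1 nitrogen, 3 oxygen; no ring) in place of a group of 8 heavy atoms (5 carbon, 1 nitrogen, 2 oxygen; no ring), on an amine nitrogen.

Two of the measured steps touch the same amine nitrogen: from compound 1 to compound 2 and from compound 2 to compound 3, and neither moved the number beyond the scatter, even though each swapped one group for a quite different one. The change from compound 2 to compound 4 is smaller in kind, keeping the same sort of group and altering only part of it. Compound 4 is therefore expected to give a number close to that of compound 2, with a step of a 1.1-fold lower number from compound 2 to compound 4 (0.05 log units; within the scatter) that stays within the scatter. Compound 4 is estimated at 7500 nM in this assay, with a range from 3000 nM to 19000 nM.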

Compound 4, half-maximal inhibitory concentration: > 100000 nM
Compound 4: a limit, no number; the forecaster's own chance of this, stated with the estimate: 5%; middle value at least 13-fold (1.12 log units) from the limit.
By their numbers in this assay, from the lowest: compounds 3, 1 and 2 (each within the scatter of the next). At a limit, above all of these: compound 4.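

In this assay compound 4 gives > 100000 nM, which is a limit of the assay and not a number: the limit of > 100000 nM in this assay, at which 1 of the 4 values shown sits. The earlier compounds shown here suggested that this amine nitrogen tolerated very different groups, including a hydrogen atom, yet compound 4 stands clearly apart from all three, with an at least 11-fold higher number from compound 2 to compound 4 (1.07 log units; beyond the scatter), an at least 23-fold higher number from compound 3 to compound 4 (1.37 log units; beyond the scatter) and an at least 20-fold higher number from compound 1 to compound 4 (1.31 log units; beyond the scatter). Among the compounds shown here, the closest comparison is the first of these, which shows that exchanging one ringless group for another on this nitrogen, the group of 10 heavy atoms in place of the group of 8 heavy atoms, can matter far more than the larger-looking exchanges among compounds 1, 2 and 3 did.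

The compounds shown do not reveal which part of the group of 10 heavy atoms goes with this step, or how far the true value of compound 4 lies past the limit. A group carrying a carboxylic acid or an amide at the same place on the chain would help to show whether the ethyl ester itself goes with the step.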